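Piperazine amide replaced by cyclohexylmethyl on the shared core

A few compounds are considered here, and "the series" means these few. Any claim that something is new, unique, unknown or untested is made for them only; others in the source may bear on it.

The three measured compounds share one core and differ only in the group on the carbonyl carbon of the piperazine amide. Compound 1 `O=C(c1ccc(Cl)cc1)N1CCN(c2nc(=O)c3cc(C(F)(F)F)cc([N+](=O)[O-])c3s2)CC1` carries a 4-chlorophenyl there, compound 2 `CCC(=O)N1CCN(c2nc(=O)c3cc(C(F)(F)F)cc([N+](=O)[O-])c3s2)CC1` an ethyl and compound 3 `O=C(c1cccc(F)c1)N1CCN(c2nc(=O)c3cc(C(F)(F)F)cc([N+](=O)[O-])c3s2)CC1` a 3-fluorophenyl. In an ADME assay on Vero cells (Chlorocebus sabaeus) for cytotoxicity, read by MTT assay, with a stated time of 72 h (a lower number here means that less compound is tolerated, a higher number that more compound is tolerated), compound 1 reaches only the limit of the assay, > 125000 nM. Compound 2 likewise stops at the limit, > 125000 nM. Compound 3 also gives no number, only the limit > 125000 nM. The steps a step that the two limits leave unreadable from compound 1 to compound 2, a step that the two limits leave unreadable from compound 1 to compound 3 and a step that the two limits leave unreadable from compound 2 to compound 3 therefore cannot be sized, because all three values sit at the limit of > 125000 nM in this assay, at which 3 of the 3 values shown sit. Compound 3 stands level with the other two at that limit, with no order among them.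

Compound 4 `O=c1nc(N2CCN(CC3CCCCC3)CC2)sc2c([N+](=O)[O-])cc(C(F)(F)F)cc12` brings a different kind of change: cyclohexylmethyl in place of (3-fluorophenyl)carbonyl on an amine nitrogen in a ring. The carbonyl and its aromatic ring leave, and a saturated ring on a one-carbon link enters on the amine nitrogen in the ring. Among the compounds with values here, none of the measured steps covers such a change, and each of them is unreadable in any case, so they set no direction. For compound 4 the estimated step of an at least 1.3-fold lower number from compound 3 to compound 4 (0.14 log units; that floor lies within the scatter) is expected to be modest, with no firm sign. Compound 4 is estimated at 90000 nM, within 30000 nM to 150000 nM, and the assay may again return only its limit.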

Compound 4, half-maximal cytotoxic concentration: > 125000 nM
Compound 4 was reported as a limit (the forecaster's own chance of this, stated with the estimate: 45%); at least 1.3-fold (0.14 log units) between middle value and limit.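

In this assay compound 4 also gives only a limit, > 125000 nM. No step from compound 1, compound 2 or compound 3 to compound 4 can be read, because all four compounds stop at the same value: the limit of > 125000 nM in this assay, at which 4 of the 4 values shown sit.

The compounds shown leave open where the tolerated concentration of each lies and whether the groups on the amine nitrogen differ at all.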